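Trimming the halogenated ring: what compound 4 may give

The source may hold more compounds than are shown below. What is called first, only, known or untested is meant among the compounds shown, and "the series" means these compounds.

Three measured compounds share one core and differ only in the group on a double-bonded chain carbon bound to a double-bonded ring carbon. In an assay on HeLa cells for inhibition of Kinesin-like protein KIF15 (Homo sapiens), read by microscopy, with stated times of 2 s and 20 s, tested at 750 nM (a higher number here means more inhibition at the concentration tested (going by the name of the read-out), a lower number less inhibition), compound 1 `O=C1Nc2ccc(C(=O)c3ccco3)cc2/C1=C/c1cc(Br)c(O)c(Br)c1` gives 65%. Compound 2 `O=C1Nc2ccc(C(=O)c3ccco3)cc2/C1=C/c1cc(I)c(O)c(I)c1` gives 26% in this assay, and compound 3 `O=C1Nc2ccc(C(=O)c3ccco3)cc2/C1=C/c1cc(F)c(O)c(Br)c1` gives 38%. Compound 3 therefore stands second of the three, with the step of a number 12 percentage points higher from compound 2 to compound 3 (beyond the scatter) on one side and the step of a number 27 percentage points lower from compound 1 to compound 3 (beyond the scatter) on the other. Putting 4-hydroxy-3,5-diiodophenyl in place of 3,5-dibromo-4-hydroxyphenyl gave a number 39 percentage points lower from compound 1 to compound 2 (beyond the scatter).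

Compound 4 `O=C1Nc2ccc(C(=O)c3ccco3)cc2/C1=C/c1ccc(Br)c(O)c1` is the next step: a group of 8 heavy atoms (6 carbon, 1 oxygen, 1 bromine; one six-membered aromatic ring of carbon only) in place of a group of 9 heavy atoms (6 carbon, 1 oxygen, 1 fluorine, 1 bromine; one six-membered aromatic ring of carbon only), on a double-bonded chain carbon bound to a double-bonded ring carbon. The ring keeps one bromine and the hydroxyl, while the fluorine is gone. Among the measured compounds shown here, no measured step removes a halogen outright; the closest guides are a number 27 percentage points lower from compound 1 to compound 3 (beyond the scatter), where fluoro replaced bromo, and a number 39 percentage points lower from compound 1 to compound 2 (beyond the scatter), where iodines replaced bromines. Since both of those steps away from compound 1 ran downward, compound 4 is expected to fall further, with the step estimated as a number 13 percentage points lower from compound 3 to compound 4 (beyond the scatter), though the size is uncertain. Compound 4 is expected to give about 25%, likely between 5% and 50%.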

Compound 4, a percentage reported as inhibition, at one concentration (the size of the read-out at that concentration, not a potency): -5.6%
Estimate against measurement, compound 4: 30.6 percentage points above, and the stated range ends above it.
By their numbers in this assay, from the lowest: compound 4; then compound 2; then compound 3; then compound 1.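

In this assay, among the compounds shown here, this position proves far less forgiving than the earlier compounds suggested: the reading shows a number 43.6 percentage points lower from compound 3 to compound 4 (beyond the scatter), and compound 4 stands lowest of the four, with a number 31.6 percentage points lower from compound 2 to compound 4 (beyond the scatter) and a number 70.6 percentage points lower from compound 1 to compound 4 (beyond the scatter). Its reading falls below zero, so no inhibition appears at the concentration tested, whereas compounds 1, 2 and 3, each with two halogen atoms on the ring, all retain a measurable effect. The group names also show that 4-bromo-3-hydroxyphenyl differs from 3,5-dibromo-4-hydroxyphenyl in more than its halogen count, since the hydroxyl carries a different number, so these steps combine two changes in one.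

Nothing available explains the loss of inhibition. Going by these compounds, it remains open which of the two changes matters more, and whether a 3,5-dichloro-4-hydroxyphenyl group, with chlorine in place of bromine, or a methoxy group in place of the hydroxyl, would retain the inhibition seen with compound 1.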